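This account rests on a few compounds, and the source may have more. Where it says the series, first, only, none or still open, it means among the compounds named here.

Of the compounds shown here, three sharing one core have been read in a functional assay on DWD cells (Homo sapiens) for inhibition, read by sulforhodamine B assay; a higher number here means a weaker inhibitor of growth, a lower number a stronger inhibitor of growth. Compound 1 `Fc1ccc(-c2ccc(-c3ccc(-c4nc5ccccc5[nH]4)cc3)cc2)cc1` gives 35600 nM, compound 2 `FC(F)(F)Oc1ccc(-c2ccc(-c3ccc(-c4nc5ccccc5[nH]4)cc3)cc2)cc1` gives 100000 nM, and compound 3 `Oc1ccc(-c2ccc(-c3ccc(-c4nc5ccccc5[nH]4)cc3)cc2)cc1` gives 46300 nM. Compound 3 stands nearest compound 1 and furthest from compound 2. The two measured steps that place it are a 1.3-fold higher number from compound 1 to compound 3 (0.11 log units; within the scatter) and a 2.2-fold lower number from compound 2 to compound 3 (0.33 log units; beyond the scatter).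

Compound 4 `COc1ccc(-c2ccc(-c3ccc(-c4nc5ccccc5[nH]4)cc3)cc2)cc1OC` has yet to be measured in this assay. It carries 3,4-dimethoxyphenyl in place of the 4-hydroxyphenyl of compound 3: 3,4-dimethoxyphenyl in place of 4-hydroxyphenyl on an aromatic carbon. Among the compounds with values here, no measured step makes this exact exchange. The closest guide is the swap of one group on that same ring for another, and the largest such step, a 2.8-fold higher number from compound 1 to compound 2 (0.45 log units; beyond the scatter), is only modest. A step of about that size at most is therefore expected, with a slight lean towards a higher number, as that step showed.

The estimated change is a 1.3-fold higher number from compound 3 to compound 4 (0.10 log units; within the scatter), which is expected to stay small. For compound 4 the estimated value is 58000 nM, with an expected range from 25000 nM to 120000 nM.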

Compound 4, concentration for 50% growth inhibition: 42100 nM
Compound 4: middle estimate off by 1.4-fold (0.14 log units), on the high side, within the range that was stated.
By their numbers in this assay, from the lowest: compounds 1, 4 and 3 (each within the scatter of the next); then compound 2.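

In this assay, 3,4-dimethoxyphenyl was exchanged for 4-hydroxyphenyl (a 1.1-fold lower number from compound 3 to compound 4 (0.04 log units; within the scatter)) and for 4-fluorophenyl (a 1.2-fold higher number from compound 1 to compound 4 (0.07 log units; within the scatter)), and neither step goes beyond the scatter. The exchange for 4-hydroxyphenyl removes the hydrogen-bond donor and adds heavy atoms on an aromatic carbon para to a large group, so among these compounds neither difference sets compound 4 apart from compound 3, which the earlier single-group exchanges could not show. No evidence is at hand on what lies behind this result.

The compounds shown leave open whether an amine or a carboxylic acid on this ring, or a longer alkoxy chain in place of methoxy, would move the number beyond the scatter. They also leave open whether either methoxy group alone would read the same as 3,4-dimethoxyphenyl.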